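Two ring stereocentres inverted on the sugar of compound 2

The source may hold more compounds than are shown below. What is called first, only, known or untested is meant among the compounds shown, and "the series" means these compounds.

Measured compounds:
compound 1 `C=C[C@@](C)(CC[C@H]1C(C)=CC[C@H]2C(C)(C)CCC[C@]12C)O[C@@H]1O[C@@H](C)[C@@H](OC(C)=O)[C@H](O)[C@H]1O` — 3.8 ug/mL
compound 2 `C=C[C@@](C)(CC[C@H]1C(C)=CC[C@H]2C(C)(C)CCC[C@]12C)O[C@@H]1O[C@H](C)[C@H](O)[C@H](O)[C@H]1O` — 4.2 ug/mL

In a functional assay on XF498 cells (Homo sapiens) for cytotoxicity, read by sulforhodamine B assay (on this read-out lower numbers stand for an effect already at smaller amounts and higher numbers for an effect only at larger amounts of compound), compound 2 gives 4.2 ug/mL. Compound 1 gives 3.8 ug/mL in this assay, and the two numbers lie within the usual scatter of each other, so neither is set apart. Among the measured compounds shown here, compound 3 `C=C[C@@](C)(CC[C@H]1C(C)=CC[C@H]2C(C)(C)CCC[C@]12C)O[C@@H]1O[C@@H](C)[C@@H](O)[C@H](O)[C@H]1O` has not yet been measured in this assay. the two compounds have the same atoms and bonds and differ only in configuration as drawn: 2 of 9 stereo elements differ; a stereocentre at a saturated ring carbon is drawn R in compound 2 and S in compound 3; a stereocentre at a saturated ring carbon is drawn R in compound 2 and S in compound 3 No measured step of this kind is available between the two known compounds. The step of no change at the digits printed from compound 2 to compound 3 (within the scatter) is therefore expected to stay within the scatter, with no clear direction. Compound 3 is accordingly estimated at 4.2 ug/mL, in a range from 2 ug/mL to 9 ug/mL.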

Compound 3, concentration for half-maximal effect: 8.9 ug/mL
Beside the measured number, compound 3's estimate is 2.1-fold (0.33 log units) below it; low and high end bracket the measured number.
By their numbers in this assay, from the lowest: compounds 1 and 2 (each within the scatter of the next); then compound 3.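

The result shows that in this assay the drawn configuration of the sugar can matter, with a 2.1-fold higher number from compound 2 to compound 3 (0.33 log units; beyond the scatter). This step rests on configuration alone: the fact that compounds 2 and 3 differ only in the configuration as drawn. Hydrogen in place of acetyl on an oxygen on a saturated carbon also counts, with a 2.3-fold higher number from compound 1 to compound 3 (0.37 log units; beyond the scatter), so on this sugar the acetyl goes with the lower number.

Which of the two inverted stereocentres carries the step stays open. So does how a longer acyl chain, such as butyryl in place of acetyl on that oxygen, would read.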